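Hydrazide series: methylphenyl swap on a second core

A few compounds are considered here, and "the series" means these few. Any claim that something is new, unique, unknown or untested is made for them only; others in the source may bear on it.

Measured so far:
- compound 1, `Cc1ccccc1C(=O)NNC(=O)c1ccc(NS(=O)(=O)c2cnc(O)nc2O)cc1`: 15100 nM
- compound 2, `Cc1ccc(C(=O)NNC(=O)c2ccc(NS(=O)(=O)c3cnc(O)nc3O)cc2)cc1`: 15900 nM
- compound 3, `Cc1ccccc1C(=O)NNC(=O)c1ccccc1NS(=O)(=O)c1cnc(O)nc1O`: 5450 nM

Three compounds have been run in a functional assay on A549 cells (Homo sapiens) for antiproliferative activity, read by MTT assay, with a stated time of 24 h; on this read-out higher numbers stand for weaker inhibition and lower numbers for stronger inhibition. Compound 1 and compound 2 share one core and differ only in the group on the carbonyl carbon: 4-methylphenyl in place of 2-methylphenyl on a carbonyl carbon. That change gave a 1.1-fold higher number from compound 1 to compound 2 (0.02 log units; within the scatter), so on this core the two methylphenyl groups cannot be told apart.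

Compound 3 carries a second core; how it differs from the core of compound 1 is not broken down here. In this assay compound 3 gives 5450 nM, the lowest number of the three, and its gaps to compound 1 and compound 2 lie beyond the scatter.

Compound 4, `Cc1ccc(C(=O)NNC(=O)c2ccccc2NS(=O)(=O)c2cnc(O)nc2O)cc1`, has not been measured. It stands to compound 3 as compound 2 stands to compound 1: 4-methylphenyl in place of 2-methylphenyl on a carbonyl carbon, the same change at the same place, a carbonyl carbon bonded to an amide-type nitrogen. Among the compounds with values here, with only one earlier instance of this change, the expectation rests on compound 1 and compound 2, where the step was a 1.1-fold higher number from compound 1 to compound 2 (0.02 log units; within the scatter). The step from compound 3 to compound 4 is therefore estimated at a 1.1-fold higher number from compound 3 to compound 4 (0.04 log units; within the scatter), again within the scatter. Compound 4 is estimated at 6000 nM in this assay, with a likely range of 3000 nM to 12000 nM, since a single earlier step on a different core gives limited grounds for a narrower call.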

Compound 4, half-maximal inhibitory concentration: > 20000 nM
Compound 4 ended at the assay's limit (the forecaster's own chance of this, stated with the estimate: 3%); at least 3.3-fold (0.52 log units) between middle value and limit.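

On the core of compound 3, 4-methylphenyl in place of 2-methylphenyl on a carbonyl carbon gives an at least 3.6-fold higher number from compound 3 to compound 4 (0.56 log units; beyond the scatter) in this assay, and this does not repeat the result on the core of compound 1: the same change on two cores in this assay, a 1.1-fold higher number (0.02 log units; within the scatter) from compound 1 to compound 2 and an at least 3.6-fold higher number (0.56 log units; beyond the scatter) from compound 3 to compound 4, at least 3.4-fold (0.54 log units) apart, beyond the scatter of two such steps. On these data alone, compound 4 gives > 20000 nM, which is a limit of the assay and not a number, so the full size of the step on this core remains unknown: the limit of > 20000 nM in this assay, at which 1 of the 4 values shown sits. The two steps show that, among these four compounds, the outcome of this change cannot be carried from one core to the other, but with a single pair on each core they do not show why, or how the change would behave on any further core.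

Still open, as far as these compounds go, is whether the dependence on the core extends to other groups on the same carbonyl carbon, such as an unsubstituted phenyl, a benzyl or a cyclohexyl group. Also open, from the compounds shown here alone, is how each core responds when an amine or a carboxylic acid takes the place of the methyl group on the phenyl ring.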